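A Chloro Group Gives Way to Anilino

A few compounds are considered here, and "the series" means these few. Any claim that something is new, unique, unknown or untested is made for them only; others in the source may bear on it.

In an ADME assay on LLC-PK11 cells (Sus scrofa) for cytotoxicity (on this read-out higher numbers stand for weaker inhibition and lower numbers for stronger inhibition), compound 1 (`Clc1ccc2cc(NCCNc3nc(NC4CCCCC4)nc(N4CCCCC4)n3)cnc2c1`) gives 27000 nM as its number and compound 2 (`Clc1ccc2cc(NCCNc3nc(Cl)nc(Nc4ccccc4)n3)cnc2c1`) gives 32800 nM as its number. These two values lie within the usual scatter of each other, so compound 2 stands level with compound 1. Compound 3 (`Clc1ccc2cc(NCCNc3nc(Nc4ccccc4)nc(Nc4ccccc4)n3)cnc2c1`) keeps the rest of compound 2 but carries anilino in place of chloro on an aromatic carbon. Going by the values given here, no measured pair of compounds isolates a change at this place, so the data offer only indirect guidance. Compound 1 and compound 2 differ in more than one place, yet their values show no gap beyond the scatter. A small change is therefore expected. The estimate is a 1.3-fold lower number from compound 2 to compound 3 (0.12 log units; within the scatter) and that expected step lies within the scatter, so no firm direction is claimed. The estimate for compound 3 is 25000 nM and the range expected around it runs from 9000 nM up to 70000 nM at its ends.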

Compound 3, half-maximal inhibitory concentration: 11200 nM
The estimate for compound 3 lay 2.2-fold (0.35 log units) above the measured number; the measured number falls inside the stated range.
By their numbers in this assay, from the lowest: compound 3; then compounds 1 and 2 (each within the scatter of the next).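

Going by these compounds alone, compound 2 and compound 3 form the only pair here that isolates this place on the aromatic carbon, and in this assay anilino in place of chloro gives a 2.9-fold lower number from compound 2 to compound 3 (0.47 log units; beyond the scatter) as a step beyond the scatter. Within the data shown here, a lower number stands for stronger inhibition, so this read-out responds modestly to what sits at this position, which the earlier compounds could not show. No measurement shown accounts for the size or direction of this step.

Anilino brings both a ring and a nitrogen with its hydrogen, and this single step cannot tell which of the two matters. A methylamino group would keep the nitrogen without the ring, a phenyl group would keep the ring without the nitrogen, and either at this place could help to separate the two.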